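The compounds below may be only part of what the source reports. "The series", "measured", "known", "first", "only" and "open" are said of these compounds alone.

Working notes on the series.

The shared core carries a substituted phenyl ether. Compound 1 `NC(=O)[C@@H]1CC[C@H](c2ccc(OCc3ccc(F)cc3)cc2)N1` bears a 4-fluorobenzyl ether; compound 2 `NC(=O)[C@@H]1CC[C@H](c2ccc(OCc3ccccc3)cc2)N1` the unsubstituted benzyl ether; compound 3 `NC(=O)[C@@H]1CC[C@H](c2ccc(Oc3ccccc3)cc2)N1` a phenyl ether. In an assay on HEK293 cells for inhibition of sodium channel protein type 3 subunit alpha (Homo sapiens), read by electrophysiology, with a stated time of 3.5 min (on this read-out lower numbers stand for stronger inhibition and higher numbers for weaker inhibition), compound 2 gives only a limit, > 63000 nM. Compound 1 likewise gives only a limit in this assay, > 63000 nM. Compound 3 gives 100000 nM in this assay. Compound 2 therefore stands at the limit, with one of the two other values also at a limit; the step that the two limits leave unreadable from compound 1 to compound 2 is unreadable, as is the step that the limit leaves unreadable from compound 2 to compound 3, both because of the limit of > 63000 nM in this assay, at which 2 of the 3 values shown sit.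

Compound 4 `NC(=O)[C@@H]1CC[C@H](c2ccc(OCc3cccc(F)c3)cc2)N1` differs from compound 2 by fluoro in place of hydrogen on an aromatic carbon. Among the measured compounds shown here, the one fluorine step measured, a step that the two limits leave unreadable from compound 1 to compound 2, sits between two limits and gives no size, and compound 3 shows that a related ether also reads as essentially inactive. No step beyond the scatter is expected; the expected step is a step that the limit leaves unreadable from compound 2 to compound 4. Compound 4 is expected to give 90000 nM in this assay, within 50000 nM to 200000 nM, most likely reported as a limit.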

Compound 4, half-maximal inhibitory concentration: > 100000 nM
Compound 4 was reported as a limit; the forecaster's own chance of this, stated with the estimate: 75%; middle value at least 1.1-fold (0.04 log units) away from the limit.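

Compound 1, compound 2 and compound 4 all give only limits in this assay, and no size can be read for the steps linking compound 4 to compound 2 or compound 1. The compounds shown leave open whether fluoro on the benzyl ether changes inhibition at all.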